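A sulfonyl aryl swap from a chloropyridine to dichlorophenyl

A few compounds are considered here, and "the series" means these few. Any claim that something is new, unique, unknown or untested is made for them only; others in the source may bear on it.

For the measured compounds named here, the series shares a core that carries a sulfonyl group on a ring nitrogen, and the three measured members differ in the aryl group on that sulfur. Compound 1 `CC1CCN(C2CCN(S(=O)(=O)c3cccnc3Cl)CC2)CC1` is the chloropyridine member. In a functional assay on DLD-1 cells (Homo sapiens) for antiproliferative activity, read by CellTiter-Glo, with a stated time of 72 h (on this read-out lower numbers stand for stronger inhibition and higher numbers for weaker inhibition), compound 1 gives only a limit of the assay, > 5000 nM, so its true value is not known; it sits at the edge described by the limit of > 5000 nM in this assay, at which 1 of the 3 values shown sits. Compound 2 `C#CCCC(=O)CC1CCN(C2CCN(S(=O)(=O)c3c(C)cc(C)cc3C)CC2)CC1` gives 3 nM in this assay. Compound 3 `CC1CCN(C2CCN(S(=O)(=O)c3ccccc3-c3ccccc3)CC2)CC1` gives 0.96 nM in this assay. Among the numbers shown, compound 1 therefore stands apart as the one member whose potency could not be pinned down, while compound 2 and compound 3 both sit in the low nanomolar range.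

Compound 4 `CC1CCN(C2CCN(S(=O)(=O)c3ccc(Cl)cc3Cl)CC2)CC1` is the next member to be measured. It differs from compound 1 in one place: 2,4-dichlorophenyl in place of 2-chloropyridin-3-yl on a sulfonyl sulfur. Going by the values given here, no measured pair isolates this change, so its effect can only be expected, not read off. Given that compound 1 is a limit and that compound 2 and compound 3 show strong inhibition with other aryl groups on the same sulfur, compound 4 is expected to move toward potency, with the step from compound 1 to compound 4 estimated at an at least 83-fold lower number from compound 1 to compound 4 (1.92 log units; beyond the scatter). Compound 4 is estimated at 60 nM in this assay, in a range from 5 nM to 1500 nM.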

Compound 4, half-maximal inhibitory concentration: 1 nM
Compound 4: the middle estimate sits 60-fold (1.78 log units) above what was measured, outside the stated range (below it).
By their numbers in this assay, from the lowest: compounds 3 and 4 (each within the scatter of the next); then compound 2. At a limit, above all of these: compound 1.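

For the compounds shown here, this is the first pair that differs in one place, and it shows that the aryl group on the sulfonyl sulfur can by itself decide the outcome in this assay: with the rest of the molecule unchanged, 2,4-dichlorophenyl in place of 2-chloropyridin-3-yl gives an at least 5000-fold lower number from compound 1 to compound 4 (3.69 log units; beyond the scatter). The size of this step is a bound and not an exact figure, because compound 1 stands at a limit of the assay: the limit of > 5000 nM in this assay, at which 1 of the 4 values shown sits. The change replaces a ring with one hetero atom by a ring of carbon only and also adds a second chlorine, and this single pair cannot tell which of the two differences carries the step.

The compounds shown leave open whether a phenyl ring with a single chlorine, or a pyridine ring with two chlorines, would side with compound 1 or with compound 4. They also leave open whether a fluorine, a methoxy group or a nitrile in place of the chlorines of compound 4 would give a similar number.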